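Pyridin-4-yl for 3-fluorophenyl on the propenyl arm

A few compounds are considered here, and "the series" means these few. Any claim that something is new, unique, unknown or untested is made for them only; others in the source may bear on it.

Compound 1 `COc1ccc(/C=C/C[C@@H]2C[C@@H]([C@@H](OC(C)=O)c3ccc(OC)c(OC)c3)CO[C@H]2c2ccc(OC)c(OC)c2)cc1OC` in a functional assay on HeLa cells (Homo sapiens) for cytotoxicity, read by WST assay, with a stated time of 48 h (a higher number here means a weaker inhibitor, a lower number a stronger inhibitor), gives > 100000 nM, which is a limit of the assay and not a number.
Compound 2 `O[C@@H](c1ccccc1)[C@H]1CO[C@H](c2ccccc2)[C@@H](C/C=C/c2cccc(F)c2)C1` in this assay gives 8380 nM.
Compound 3 `COc1cccc([C@H]2OC[C@H]([C@@H](O)c3ccc(OC)c(OC)c3)C[C@@H]2C/C=C/c2ccc(OC)c(OC)c2)c1` in this assay gives 21800 nM.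

Compound 2 holds the lowest of the two real numbers in this assay; compound 3 sits higher, and that gap is beyond the usual scatter. Compound 1 contributes only a limit, as summarised by the limit of > 100000 nM in this assay, at which 1 of the 3 values shown sits, and so cannot be ranked against the others.

Compound 4 `O[C@@H](c1ccccc1)[C@H]1CO[C@H](c2ccccc2)[C@@H](C/C=C/c2ccncc2)C1` differs from compound 2 in a single place: pyridin-4-yl in place of 3-fluorophenyl on a double-bonded chain carbon bound to a double-bonded chain carbon. Among the compounds with values here, no measured pair in this set carries the same change, so nothing here fixes the size or direction of the step in advance. The working expectation is a modest weakening, the step from compound 2 to compound 4 being estimated at a 1.6-fold higher number from compound 2 to compound 4 (0.19 log units; within the scatter), roughly at the edge of the scatter. Compound 4 is therefore expected to give about 13000 nM in this assay, with a plausible range from 4000 nM to 45000 nM.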

Compound 4, half-maximal inhibitory concentration: > 100000 nM
Compound 4: a limit, no number; the forecaster's own chance of this, stated with the estimate: 10%; at least 7.6-fold (0.88 log units) between middle value and limit.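

In this assay, pyridin-4-yl in place of 3-fluorophenyl on a double-bonded chain carbon bound to a double-bonded chain carbon gives an at least 11-fold higher number from compound 2 to compound 4 (1.07 log units; beyond the scatter). Within the data shown here, this is the first single-place comparison, and it shows that changing the aromatic ring on the propenyl arm alone, with the shared core kept, can carry a compound from a measured value to the limit of the assay. The value of compound 4 is a limit and not a number, so only the lower end of the step is fixed, and the series now has two compounds that cannot be ranked: the limit of > 100000 nM in this assay, at which 2 of the 4 values shown sit.

From the compounds shown here alone, whether the loss belongs to the pyridin-4-yl group as such or to the absence of fluorine stays open. Plain phenyl, pyridin-3-yl or 4-fluorophenyl on the same arm would separate these readings.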